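This account rests on a few compounds, and the source may have more. Where it says the series, first, only, none or still open, it means among the compounds named here.

In an assay on CHO cells for positive allosteric modulation of metabotropic glutamate receptor 5 (Homo sapiens), read by FLIPR (on this read-out lower numbers stand for an effect already at smaller amounts and higher numbers for an effect only at larger amounts of compound), the measured compounds stand as follows:
compound 1, `CCOc1cccc2c1C(=O)N(Cc1cc(Br)ccc1NC(=O)c1ccccn1)C2=O`, gives 720 nM.
Compound 2, `COc1ccc2c(c1OC)C(=O)N(Cc1cc(Cl)ccc1NC(=O)c1ccccn1)C2=O`, is reported only as a limit of the assay, > 100000 nM.
Compound 3, `O=C(Nc1ccc(Cl)cc1CN1C(=O)c2ccccc2C1=O)c1ccccc1`, is likewise reported only as a limit, > 100000 nM.

Compound 3 therefore sits at the limit of > 100000 nM in this assay, at which 2 of the 3 values shown sit, with no number of its own. The next compound, compound 4, `O=C(Nc1ccc(Cl)cc1CN1C(=O)c2ccccc2C1=O)c1ccccc1[N+](=O)[O-]`, differs from compound 3 in one place: nitro in place of hydrogen on an aromatic carbon. Among the compounds with values here, the compounds measured so far give no step that shows what this change does, and compound 1 and compound 2 share a further group yet fall on opposite sides of the limit. The step from compound 3 to compound 4 is expected to be an at least 2.5-fold lower number from compound 3 to compound 4 (0.39 log units; beyond the scatter), a move toward lower numbers that may not clear the limit. Compound 4 is estimated at 40000 nM, within 4000 nM to 100000 nM.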

Compound 4, half-maximal effective concentration: 5700 nM
Estimate against measurement, compound 4: 7.0-fold (0.85 log units) above; the measured number falls inside the stated range.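

In this assay, within the data shown here, the change from phenyl to 2-nitrophenyl gives an at least 17-fold lower number from compound 3 to compound 4 (1.24 log units; beyond the scatter) and is the first step that can be read at this aromatic carbon, ortho to a large group. It shows that this position is not indifferent: a single group here brings a compound off the limit while the rest of the molecule stays the same. From the compounds shown here alone, the full size of the step stays unknown because compound 3 has only a limit: the limit of > 100000 nM in this assay, at which 2 of the 4 values shown sit. Going by these compounds, whether an amine or a carboxylic acid at this place would do the same stays open, as does whether nitro has this effect on other cores.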